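The source may hold more compounds than are shown below. What is called first, only, known or untested is meant among the compounds shown, and "the series" means these compounds.

Measured so far:
- compound 1, `N#Cc1ncn(-c2ccc(F)cc2)c1/N=C/c1ccc(O)cc1`, 20400 nM
- compound 2, `COc1ccc(/C=N/c2c(C#N)ncn2-c2ccc(F)cc2)cc1`, 19400 nM
- compound 3, `COc1ccc(/C=N/c2c(C#N)ncn2Cc2ccc(F)cc2)cc1O`, 6140 nM

All three values come from a functional assay on HT-29 cells (Homo sapiens) for antiproliferative activity, read by MTT assay, with a stated time of 48 h; on this read-out lower numbers stand for stronger inhibition and higher numbers for weaker inhibition. Compound 1 and compound 2 share a core and differ only by methyl in place of hydrogen on an oxygen on an aromatic ring; the result was a 1.1-fold lower number from compound 1 to compound 2 (0.02 log units; within the scatter), so the two numbers cannot be told apart. Compound 3 gives the lowest number of the three, but its core differs from the core of compound 1, and that difference is not broken down here. The unmeasured compound 4, `COc1ccc(/C=N/c2c(C#N)ncn2Cc2ccc(F)cc2)cc1OC`, is made from compound 3 by methyl in place of hydrogen on an oxygen on an aromatic ring, the same change as from compound 1 to compound 2, at the same kind of place. Within the data shown here, since that earlier step stayed within the scatter, the expectation for compound 4 is a step of about a 1.0-fold lower number from compound 3 to compound 4 (0.01 log units; within the scatter), that is, a number close to the one for compound 3, because a 1.1-fold lower number from compound 1 to compound 2 (0.02 log units; within the scatter) showed no real shift. The estimate for compound 4 in this assay is 6000 nM, expected to fall between 3000 nM and 12000 nM.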

Compound 4, half-maximal inhibitory concentration: 13800 nM
For compound 4 the middle estimate is 2.3-fold (0.36 log units) below the measured one; the whole stated range lies below it.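

The swap of hydroxy to methoxy gives a 2.2-fold higher number from compound 3 to compound 4 (0.35 log units; beyond the scatter) on the core of compound 3, a modest step, against a 1.1-fold lower number from compound 1 to compound 2 (0.02 log units; within the scatter) on the core of compound 1. One step lies beyond the usual scatter and the other within it, yet set side by side the two cannot be told apart: the same change on two cores in this assay, a 1.1-fold lower number (0.02 log units; within the scatter) from compound 1 to compound 2 and a 2.2-fold higher number (0.35 log units; beyond the scatter) from compound 3 to compound 4, 2.4-fold (0.37 log units) apart, within the scatter of two such steps
So these pairs give no firm sign that the core alters what this swap does, but two pairs cannot show that it acts alike on every core in the series, and they do not explain why the number for compound 4 ended up on the higher side.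

As far as these compounds go, what a longer chain such as ethyl on this oxygen would do to the number remains open, as does the effect of an amine in place of the hydroxy. Also open, from the compounds shown here alone, is how large the step from hydroxy to methoxy would be on a third core.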